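Amine nitrogen substituent: acyl replaced by alkyl

A few compounds are considered here, and "the series" means these few. Any claim that something is new, unique, unknown or untested is made for them only; others in the source may bear on it.

Measured so far:
Compound 1 `CC(C)OC(=O)N1CCC(O[C@H]2CC[C@H](Oc3cnc(S(C)(=O)=O)cn3)CC2)CC1` gives 13.7 nM in a functional assay on isolated protein for agonist activity at Glucose-dependent insulinotropic receptor (Homo sapiens), read by HTRF and cAMP accumulation; on this read-out lower numbers stand for an effect already at smaller amounts and higher numbers for an effect only at larger amounts of compound.
Compound 2 `CS(=O)(=O)c1cnc(O[C@H]2CC[C@H](OC3CCN(C(=O)C4(C(F)(F)F)CC4)CC3)CC2)cn1` gives 107 nM in this assay.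

Among the measured compounds shown here, compound 2 stands at the higher of the two numbers, its only neighbour being compound 1, reached by the step of a 7.8-fold higher number from compound 1 to compound 2 (0.89 log units; beyond the scatter). Compound 3 `CS(=O)(=O)c1cnc(O[C@H]2CC[C@H](OC3CCN(CC4(C(F)(F)F)CCC4)CC3)CC2)cn1` differs from compound 2 by (1-(trifluoromethyl)cyclobutyl)methyl in place of (1-(trifluoromethyl)cyclopropyl)carbonyl on an amine nitrogen in a ring. For the measured compounds named here, the one measured step exchanges groups on the carbonyl carbon while the carbonyl stays; no measured step covers loss of the carbonyl itself or the change of ring size, so no direct precedent exists. Direction is therefore open; a moderate further rise in the number, a 2.3-fold higher number from compound 2 to compound 3 (0.37 log units; beyond the scatter), is expected, with wide uncertainty. For compound 3 the estimate in this assay is 250 nM, range 50 nM to 1500 nM.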

Compound 3, half-maximal effective concentration: 54.8 nM
The estimate for compound 3 lay 4.6-fold (0.66 log units) above the measured number; low and high end bracket the measured number.
By their numbers in this assay, from the lowest: compound 1; then compounds 3 and 2 (each within the scatter of the next).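

In this assay, a carbonyl on the amine nitrogen in a ring proves dispensable among these compounds: (1-(trifluoromethyl)cyclobutyl)methyl in place of (1-(trifluoromethyl)cyclopropyl)carbonyl keeps the number level (a 2.0-fold lower number from compound 2 to compound 3 (0.29 log units; within the scatter)). Isopropoxycarbonyl still holds the lowest number of the three, with (1-(trifluoromethyl)cyclobutyl)methyl in its place giving a clear loss (a 4.0-fold higher number from compound 1 to compound 3 (0.60 log units; beyond the scatter)). Nothing at hand explains either step.

On these data alone, the step from compound 2 to compound 3 changes carbonyl and ring size together, so their separate shares stay open. Also open, as far as these compounds go, is how a plain isopropyl or a longer alkyl chain on this nitrogen would read.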